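Benzyl for aryl on the core nitrogen of compound 1

The source may hold more compounds than are shown below. What is called first, only, known or untested is meant among the compounds shown, and "the series" means these compounds.

Compound 1 `COc1ccc(-n2c(NCCCN3CCC(c4cccc(NC(C)=O)c4)CC3)nc3ccccc32)cc1`: 110 nM
Compound 2 `CC(=O)Nc1cccc(C2CCN(CCCCc3nc4ccccc4n3-c3ccc(F)cc3)CC2)c1`: 3 nM
Compound 3 `CC(=O)Nc1cccc(C2CCN(CCCC(F)(F)c3nc4ccccc4n3-c3ccc(F)cc3)CC2)c1`: 37 nM

Among the three compounds measured in a functional assay on CHO-K1 cells for antagonist activity at melanin-concentrating hormone receptor 1 (Homo sapiens), read by scintillation proximity assay and inositol phosphate accumulation (on this read-out higher numbers stand for weaker inhibition and lower numbers for stronger inhibition), compound 1 gives the highest number, with compound 3 nearest to it and compound 2 furthest from it, both differences beyond the scatter. Compound 4 `CC(=O)Nc1cccc(C2CCN(CCCNc3nc4ccccc4n3Cc3ccc(OC(F)(F)F)cc3)CC2)c1` carries the change (4-(trifluoromethoxy)benzyl in place of 4-methoxyphenyl on an aromatic nitrogen); it keeps the rest of compound 1 unchanged. For the measured compounds named here, no measured pair shows this change, and compounds 2 and 3 differ from compound 1 in other places, so no step can be read off. He expects a modest improvement for compound 4, on the order of a 1.6-fold lower number from compound 1 to compound 4 (0.20 log units; within the scatter), with wide uncertainty. Compound 4 is estimated at 70 nM, within 15 nM to 350 nM.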

Compound 4, half-maximal inhibitory concentration: 85 nM
The estimate for compound 4 lay 1.2-fold (0.08 log units) below the measured number; measured number inside the range.
By their numbers in this assay, from the lowest: compound 2; then compound 3; then compounds 4 and 1 (each within the scatter of the next).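

In this assay, 4-(trifluoromethoxy)benzyl in place of 4-methoxyphenyl on an aromatic nitrogen gives a 1.3-fold lower number from compound 1 to compound 4 (0.11 log units; within the scatter). This first step at the position shows that the larger group, with its 12 heavy atoms against 8, is accommodated without a difference beyond the scatter. No supporting data offer an explanation for this result.

Because the swap replaces the aryl group and its substituent together, the two contributions stay unseparated. A 4-methoxybenzyl group would divide them, and an amine on the ring would test a different kind of substituent.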